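Amide series: propyl to cyclohexyl on the nitrogen

A few compounds are considered here, and "the series" means these few. Any claim that something is new, unique, unknown or untested is made for them only; others in the source may bear on it.

Measured so far in a functional assay on NTUB1 cells (Homo sapiens) for cytotoxicity, read by MTT assay, with a stated time of 72 h (a lower number here means a stronger inhibitor, a higher number a weaker inhibitor), for the series:
compound 1 `COc1ccc(OC)c(C(=O)/C=C/c2ccc(C(=O)OCc3ccccc3)cc2)c1` gives 13300 nM
compound 2 `CCNC(=O)c1ccc(/C=C/C(=O)c2cc(OC)ccc2OC)cc1` gives 3760 nM
compound 3 `CCCNC(=O)c1ccc(/C=C/C(=O)c2cc(OC)ccc2OC)cc1` gives 2260 nM

Compound 3 stands level with compound 2 and clear of compound 1. Replacing benzyloxy on the carbonyl carbon gave a 3.5-fold lower number from compound 1 to compound 2 (0.55 log units; beyond the scatter) and also a 5.9-fold lower number from compound 1 to compound 3 (0.77 log units; beyond the scatter) in these two amides. The added methyl on the chain gave a 1.7-fold lower number from compound 2 to compound 3 (0.22 log units; within the scatter) and so no step beyond the scatter.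

Compound 4 `COc1ccc(OC)c(C(=O)/C=C/c2ccc(C(=O)NC3CCCCC3)cc2)c1` is not yet measured. Its change from compound 3 is cyclohexyl in place of propyl on an amide-type nitrogen in the form of cyclohexyl in place of propyl on an amide-type nitrogen. Within the data shown here, only the step of a 1.7-fold lower number from compound 2 to compound 3 (0.22 log units; within the scatter) varies the group on this nitrogen, and no ring has been measured there, so the range stays wide. The expected step in this assay is a 1.1-fold lower number from compound 3 to compound 4 (0.05 log units; within the scatter) and so nothing beyond the scatter. For compound 4 an estimated 2000 nM (range 800 nM to 5500 nM) is expected.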

Compound 4, half-maximal inhibitory concentration: 2250 nM
Estimate against measurement, compound 4: 1.1-fold (0.05 log units) below; the measured number falls inside the stated range.
By their numbers in this assay, from the lowest: compounds 4, 3 and 2 (each within the scatter of the next); then compound 1.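

In this assay a six-membered carbon ring on the amide-type nitrogen sits level with the open chains: cyclohexyl gives a 1.0-fold lower number from compound 3 to compound 4 (0.00 log units; within the scatter) and a 1.7-fold lower number from compound 2 to compound 4 (0.22 log units; within the scatter) so ethyl, propyl and cyclohexyl cannot be told apart at this position. The ring also keeps compound 4 clear of the benzyloxy compound, with a 5.9-fold lower number from compound 1 to compound 4 (0.77 log units; beyond the scatter) in the same range as the two steps from compound 1 to the chain amides. No measurement among those shown accounts for this flat response to the group on the nitrogen.

Going by these compounds, whether a longer chain, a branched chain such as isopropyl, or an aromatic ring such as phenyl on this nitrogen stays at this level remains open. Also open, on these data alone, is what happens when the amide hydrogen is replaced, as in a dimethylamide or a piperidine amide, or when a hydroxyl or an amine is carried on the cyclohexyl ring.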